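Working notes on compounds 1 to 3: a benzyl step

A few compounds are considered here, and "the series" means these few. Any claim that something is new, unique, unknown or untested is made for them only; others in the source may bear on it.

compound 1 `Cc1cc(O)n(-c2nc3ccccc3[nH]2)n1`: 3600 nM
compound 2 `Cc1[nH]n(-c2nc3c(C)cccc3[nH]2)c(=O)c1C`: > 10000 nM

Within the data shown here, compound 1 is the only member of the set with a numerical value: in an assay on isolated protein for inhibition of alpha-ketoglutarate-dependent dioxygenase alkB homolog 3 (Homo sapiens), read by polymerase chain reaction, with a stated time of 1 h (a lower number here means a stronger inhibitor, a higher number a weaker inhibitor), compound 1 gives 3600 nM. For compound 2 this assay reports only a limit, > 10000 nM, so compound 1 cannot be ordered against it beyond the observation that (the limit of > 10000 nM in this assay, at which 1 of the 2 values shown sits). Among the measured compounds shown here, no pair of measured compounds differing in a single place is available, so no measured step exists to lean on.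

Compound 3, `Cc1nn(-c2nc3ccccc3[nH]2)c(O)c1Cc1ccccc1`, is built from compound 1 by one change: benzyl in place of hydrogen on an aromatic carbon. For the measured compounds named here, with no comparable step recorded, the expectation for this change is a step from compound 1 that stays within the usual scatter in either direction, a 1.2-fold lower number from compound 1 to compound 3 (0.08 log units; within the scatter) being the estimated size. Compound 3 is therefore estimated at 3000 nM in this assay, with the likely span from 800 nM to 10000 nM.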

Compound 3, half-maximal inhibitory concentration: 480 nM
Beside the measured number, compound 3's estimate is 6.3-fold (0.80 log units) above it; measured number outside the range, below it.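

In this assay, the aromatic carbon of the five-membered aromatic ring with 2 nitrogen, next to the ring atom that bears a hydroxy group and next to the ring atom that bears a methyl group, now has a measured step: benzyl in place of hydrogen gives a 7.5-fold lower number from compound 1 to compound 3 (0.88 log units; beyond the scatter) on the otherwise unchanged core. Among these compounds, this is the first comparison that isolates a single place, and it shows that this carbon can carry a group of 7 heavy atoms with one six-membered aromatic ring of carbon only, with a lower number rather than a higher one. No measured property among the compounds shown accounts for the size of this step.

With a single substituent at this carbon, the compounds shown do not separate the contribution of the aromatic ring from that of the methylene link, which a plain methyl, a longer chain such as phenethyl, or a directly attached phenyl would begin to address. Also open, as far as these compounds go, is whether the benzyl ring itself tolerates further groups, such as an amine, a carboxylic acid or a fluorine on that ring.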